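This account rests on a few compounds, and the source may have more. Where it says the series, first, only, none or still open, it means among the compounds named here.

The series shares one core, which compound 1 `c1ccc2nc3c(cc2c1)Cn1c-3nc2ccccc21` carries without substituent. For the measured compounds named here, in a functional assay on LNCaP cells (Homo sapiens) for cytotoxicity, read by MTT assay, with a stated time of 72 h (a higher number here means a weaker inhibitor, a lower number a stronger inhibitor), compound 1 gives 11300 nM, the lowest of the two numbers measured so far; its nearest neighbour is compound 2 `Clc1cccc2cc3c(nc12)-c1nc2ccccc2n1C3`, which in this assay gives 24000 nM. Going by the values given here, the only measured step is a 2.1-fold higher number from compound 1 to compound 2 (0.33 log units; beyond the scatter), chloro in place of hydrogen on an aromatic carbon. Compound 3 `Cc1ccc2cc3c(nc2c1)-c1nc2ccccc2n1C3` is not yet measured. It differs from compound 1 by methyl in place of hydrogen on an aromatic carbon. Among the compounds with values here, only the step from compound 1 to compound 2 bears on this change, and it concerns a different group; that step was modest, so in this assay a step of similar or smaller size, if any beyond the scatter, is expected, more likely toward a higher number. Compound 3 is therefore estimated at 14000 nM in this assay, within 6000 nM to 35000 nM. The expected step is a 1.2-fold higher number from compound 1 to compound 3 (0.09 log units; within the scatter).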

Compound 3, half-maximal inhibitory concentration: 39000 nM
Beside the measured number, compound 3's estimate is 2.8-fold (0.44 log units) below it; measured number outside the range, above it.
By their numbers in this assay, from the lowest: compound 1; then compounds 2 and 3 (each within the scatter of the next).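

Methyl on this aromatic carbon, meta to a fused ring and para to a fused ring, brings a 3.5-fold higher number from compound 1 to compound 3 (0.54 log units; beyond the scatter) in this assay and so shows that this small hydrocarbon group does not lower the number here. The step for chloro, a 2.1-fold higher number from compound 1 to compound 2 (0.33 log units; beyond the scatter) in this assay, runs the same way, so compound 1 without substituent keeps the lowest number of the three, and neither substituent shown improves on it. Nothing available explains why methyl raises the number at this position.

From the compounds shown here alone, whether any group on this carbon can lower the number remains open, and a methoxy group, an amine or a carboxylic acid there would test that. Also open, going by these compounds, is how much of each step belongs to the group and how much to its place, which chloro and methyl on the same carbon would separate.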